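Double-bond configuration at the tert-butoxy end of the series

The compounds below may be only part of what the source reports. "The series", "measured", "known", "first", "only" and "open" are said of these compounds alone.

- compound 1 `CCCCCCCCCCCC/C=C\N(NC(=O)COC)C(=O)CCCCCCCCC` gives 108000 nM in a functional assay on HeLa cells (Homo sapiens) for cytotoxicity, with a stated time of 72 h; a higher number here means that more compound is tolerated, a lower number that less compound is tolerated
- compound 2 `CCCCCCCCCCCC/C=C\N(NC(=O)COC)C(=O)OC(C)(C)C` gives 85300 nM
- compound 3 `CCCCCCCCCCN(NC(=O)COC)C(=O)OC(C)(C)C` gives 104000 nM

Compound 2 stands within the scatter of both other measured compounds, so the three values in this assay show no order. The next compound is compound 4 `CCCCCCCCCCCC/C=C/N(NC(=O)COC)C(=O)OC(C)(C)C`, and its relation to compound 2 is simple (the two compounds have the same atoms and bonds and differ only in configuration as drawn: 1 of 1 stereo elements differ; a double bond is drawn Z in compound 2 and E in compound 4). Among the compounds with values here, no measured pair isolates this configuration change. Within the data shown here, the only measured step is a 1.3-fold lower number from compound 1 to compound 2 (0.10 log units; within the scatter) and concerns another part of the structure, so it bears on the series level only. Compound 3, which has no double bond, gives 104000 nM and also stays within the scatter of compound 2. Among the measured compounds shown here, nothing measured so far moves this read-out beyond the scatter, so no step beyond it is expected in this assay, and no direction is favoured. The expected change is small (a 1.1-fold higher number from compound 2 to compound 4 (0.02 log units; within the scatter)). Compound 4 is estimated at 90000 nM with an expected range from 50000 nM to 160000 nM as its limits.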

Compound 4, half-maximal cytotoxic concentration: 57700 nM
Beside the measured number, compound 4's estimate is 1.6-fold (0.19 log units) above it; the range from low to high includes it.
By their numbers in this assay, from the lowest: compounds 4, 2, 3 and 1 (each within the scatter of the next).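

The double-bond configuration now has a measured pair of its own in this assay, with a 1.5-fold lower number from compound 2 to compound 4 (0.17 log units; within the scatter). This step stays within the scatter, so with tert-butoxy on the carbonyl carbon, the Z and E forms cannot be told apart by this read-out, and the pair offers a direct comparison: the fact that compounds 2 and 4 differ only in the configuration as drawn The earlier step, a 1.3-fold lower number from compound 1 to compound 2 (0.10 log units; within the scatter), concerned another part of the structure and also stays within the scatter, so neither single-place change yet moves the read-out beyond it.

Open, on these data alone, is whether the same holds for the Z and E forms with nonyl in place of tert-butoxy. Also open, as far as these compounds go, is whether an amine or a carboxylic acid on the long chain would take this assay beyond the scatter.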